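The compounds below may be only part of what the source reports. "The series", "measured", "known", "first", "only" and "open" are said of these compounds alone.

Of the compounds shown here, three from this series have a measured number so far. Compound 1 `N#Cc1ccc(O[C@H]2CN(S(=O)(=O)c3ccc(Cl)cc3)C[C@@]2(O)CO)cc1F` gives 44 ug/mL in a physicochemical assay for solubility, in simulated intestinal fluid, with a stated time of 4 h; a lower number here means a less soluble compound, a higher number a more soluble compound. Within the data shown here, compound 2 `N#Cc1ccc(O[C@H]2CN(S(=O)(=O)c3ccc(C(F)(F)F)nc3)C[C@@]2(O)CO)cc1F` gives 98 ug/mL in this assay, and the one step recorded between measured compounds, a 2.2-fold higher number from compound 1 to compound 2 (0.35 log units; beyond the scatter), is the only change of a whole group whose effect on this assay has been seen. Compound 3 `N#Cc1ccc(O[C@H]2CN(S(=O)(=O)c3ccc(Cl)cc3Cl)C[C@@]2(O)CN)cc1F` gives 78 ug/mL in this assay; its number stands within the scatter of both compound 2 and compound 1, so it cannot be ordered against either of them.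

Compound 4 `N#Cc1ccc(O[C@H]2CN(S(=O)(=O)c3ccc(Cl)cc3Cl)C[C@@]2(O)CO)cc1F` differs from compound 3 in one place: hydroxy in place of amino on a saturated chain carbon bound to a saturated ring carbon. Among the measured compounds shown here, no measured step bears on this change, since the one recorded step alters the group on the sulfonyl sulfur and leaves the hydroxymethyl chain untouched. For the measured compounds named here, compound 4 shares its hydroxymethyl chain with compound 1 and compound 2 and its dichlorophenyl group with compound 3, but no pair of measured compounds isolates the amino-to-hydroxy exchange. The expectation therefore rests on the loss of the amino group alone, and the step of a 2.6-fold lower number from compound 3 to compound 4 (0.41 log units; beyond the scatter) is expected to be downward. The number for compound 4 in this assay is estimated at 30 ug/mL, with a range from 10 ug/mL to 90 ug/mL.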

Compound 4, solubility: 19 ug/mL
Compound 4: the middle estimate sits 1.6-fold (0.20 log units) above what was measured, and the stated range covers the measured number.
By their numbers in this assay, from the lowest: compound 4; then compounds 1, 3 and 2 (each within the scatter of the next, the first and the last beyond it).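

Among these compounds, the exchange of aminomethyl to hydroxymethyl, the first change at this place to be seen, gives in this assay a 4.1-fold lower number from compound 3 to compound 4 (0.61 log units; beyond the scatter) with the 2,4-dichlorophenyl group held constant, so a single atom on a saturated chain carbon bound to a saturated ring carbon is enough to move the number beyond the scatter. With the hydroxymethyl chain held constant, the group on the sulfonyl sulfur also proves to matter: chloro in place of hydrogen on an aromatic carbon gives a 2.3-fold lower number from compound 1 to compound 4 (0.36 log units; beyond the scatter) and 2,4-dichlorophenyl in place of 6-(trifluoromethyl)pyridin-3-yl gives a 5.2-fold lower number from compound 2 to compound 4 (0.71 log units; beyond the scatter) among these compounds, which leaves compound 4 beyond the scatter of each of the other three. No measurement at hand accounts for any of these steps.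

Going by these compounds, the aminomethyl chain appears here only with the 2,4-dichlorophenyl group, so it remains open whether the same exchange would give a step of similar size with 4-chlorophenyl or 6-(trifluoromethyl)pyridin-3-yl on the sulfonyl sulfur. On these data alone, how a dimethylamine, a carboxylic acid or a longer chain carrying the amine would compare at this place also remains open.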